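Removing one fluoro group from a weakly cytotoxic compound

The source may hold more compounds than are shown below. What is called first, only, known or untested is meant among the compounds shown, and "the series" means these compounds.

In a functional assay on PC-3 cells (Homo sapiens) for cytotoxicity, read by MTT assay, with a stated time of 72 h (a lower number here means a stronger inhibitor, a higher number a weaker inhibitor), compound 2 (`CNC(=O)c1cc(Oc2ccc(NC(=O)c3cc(-c4ccc(OC)cc4)ncn3)cc2F)ccn1`) gives 56200 nM. Among the compounds with values here, the only other measured compound, compound 1 (`CNC(=O)c1cc(Oc2ccc(NC(=O)c3cc(-c4ccccc4)ncn3)cc2)ccn1`), gives 44200 nM. These two numbers lie within the usual scatter of each other, so compound 2 cannot be told apart from compound 1 in this assay. Both numbers are large, which means that high concentrations are needed to reach half-maximal inhibition.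

Compound 3 (`CNC(=O)c1cc(Oc2ccc(NC(=O)c3cc(-c4ccc(OC)cc4)ncn3)cc2)ccn1`) differs from compound 2 in one place: hydrogen in place of fluoro on an aromatic carbon, ortho to a (2-(methylcarbamoyl)pyridin-4-yl)oxy group (hydrogen in place of fluoro on an aromatic carbon). Within the data shown here, no measured pair of compounds shows this change on its own, so there is no direct evidence for its size. Among the measured compounds shown here, the best guide is the narrow spread of the two known numbers, with compound 2 at 56200 nM and compound 1 at 44200 nM. No shift beyond the scatter is therefore expected, and the direction is only a slight lean towards a lower number. The expected step is a 1.2-fold lower number from compound 2 to compound 3 (0.07 log units; within the scatter). For compound 3 the estimated value is 48000 nM, with an expected range from 22000 nM to 100000 nM.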

Compound 3, half-maximal inhibitory concentration: 38800 nM
For compound 3 the middle estimate is 1.2-fold (0.09 log units) above the measured one; measured number inside the range.
By their numbers in this assay, from the lowest: compounds 3, 1 and 2 (each within the scatter of the next).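

Within the data shown here, compound 3 gives the first direct reading of this change on its own: in this assay, hydrogen in place of fluoro, ortho to a (2-(methylcarbamoyl)pyridin-4-yl)oxy group, amounts to a 1.4-fold lower number from compound 2 to compound 3 (0.16 log units; within the scatter) and so cannot be told apart from no effect at this position. Compound 3 also connects to compound 1 through a single change, methoxy in place of hydrogen on an aromatic carbon, and a 1.1-fold lower number from compound 1 to compound 3 (0.06 log units; within the scatter) shows that this swap also makes no difference that can be read, so all three compounds remain equally weak within the scatter. No other data bear on this result, so nothing can be said about what lies behind it.

Only fluoro and hydrogen have been compared at this position, so these numbers cannot show whether a different kind of group there, such as an amine or a carboxylic acid, would move the number beyond the scatter. From the compounds shown here alone, it also remains open whether the same fluoro swap would stay this small on a compound with a much lower number, since all three values here sit at high concentrations.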